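Replacing the selenium-bearing group of compound 1

The compounds below may be only part of what the source reports. "The series", "measured", "known", "first", "only" and "open" are said of these compounds alone.

compound 1 `CCOC(=O)c1cc([Se]c2ccc(F)cc2)c2cc(OC)ccc2n1`: 134000 nM
compound 2 `CCOC(=O)c1cc([Se]c2ccc(OC)cc2)c2cc(OC)ccc2n1`: 82500 nM

Both compounds were tested in a functional assay on Jurkat cells (Homo sapiens) for cytotoxicity, read by MTT assay, with a stated time of 24 h; on this read-out lower numbers stand for an effect already at smaller amounts and higher numbers for an effect only at larger amounts of compound. For the measured compounds named here, only these two numbers are available, and compound 1 stands within the scatter of compound 2, its sole neighbour: a 1.6-fold lower number from compound 1 to compound 2 (0.21 log units; within the scatter).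

Compound 3 `CCOC(=O)c1cc(C#CCCO)c2cc(OC)ccc2n1` has not yet been measured in this assay. Its difference from compound 1 is a larger one: a group of 5 heavy atoms (4 carbon, 1 oxygen; no ring) in place of a group of 8 heavy atoms (6 carbon, 1 fluorine, 1 selenium; one six-membered aromatic ring of carbon only), on an aromatic carbon. The entering 4-hydroxybut-1-yn-1-yl group sits opposite the ring nitrogen.

Going by the values given here, only one measured step bears on this, and it bears weakly. That step, a 1.6-fold lower number from compound 1 to compound 2 (0.21 log units; within the scatter), exchanges fluoro for methoxy on the aromatic ring that is absent from compound 3, so it does not measure the replacement itself. Among the compounds with values here, no measured compound lacks the selenium-bearing group, so the data offer no direction for the change. The expected step is therefore none beyond the scatter: a 1.1-fold higher number from compound 1 to compound 3 (0.05 log units; within the scatter), an estimate with a wide margin.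

For compound 3 the estimated value is 150000 nM, with an expected range from 60000 nM to 400000 nM.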

Compound 3, half-maximal effective concentration: 123000 nM
Beside the measured number, compound 3's estimate is 1.2-fold (0.09 log units) above it; the measured number falls inside the stated range.
By their numbers in this assay, from the lowest: compounds 2, 3 and 1 (each within the scatter of the next).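

In this assay, the exchange at the aromatic carbon opposite the ring nitrogen gives a 1.1-fold lower number from compound 1 to compound 3 (0.04 log units; within the scatter), so a 4-hydroxybut-1-yn-1-yl group stands in place of the selenium-bearing group without a step beyond the scatter. The earlier pair varied only a substituent on the aromatic ring of that group, whereas compound 3 shows that, for this pair, the read-out does not depend on selenium or on that ring being present at this position, even though the entering group differs in size and brings a triple bond and a hydrogen-bond donor. No measurement shown here speaks to what lies behind this result.

The compounds shown leave open whether any group at this position can produce a step beyond the scatter, for example a 4-aminobut-1-yn-1-yl group, a chain ending in a carboxylic acid, or a longer chain in place of the four-carbon one. They also leave open whether the triple bond or the terminal hydroxyl matters on its own, since a saturated butyl chain or a but-1-yn-1-yl group without the oxygen would be needed to separate the two.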